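This account rests on a few compounds, and the source may have more. Where it says the series, first, only, none or still open, it means among the compounds named here.

Measured so far in a functional assay on K562 cells (Homo sapiens) for inhibition; on this read-out lower numbers stand for stronger inhibition and higher numbers for weaker inhibition:
- compound 1 (`CC1(C)OC2OC(C(O)CO)C(OC(=O)C(C)(C)C)C2O1`) gives 1500000 nM
- compound 2 (`CC(C)C(=O)OC1C(C(O)CO)OC2OC(C)(C)OC21`) gives 2500000 nM

Only these two numbers exist, and they lie within the usual scatter of each other, so compound 1 stands level with compound 2 and neither can be ranked above the other.

Compound 3 (`CCCCC(=O)OC1C(C(O)CO)OC2OC(C)(C)OC21`) has not yet been measured. It keeps the core of compound 1 and differs in one group: butyl in place of tert-butyl on a carbonyl carbon. In words, this is butyl in place of tert-butyl on a carbonyl carbon, and the two groups hold the same atoms, joined differently.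

Within the data shown here, one measured step bears on this change, since it also alters the group on that carbonyl carbon: a 1.7-fold higher number from compound 1 to compound 2 (0.22 log units; within the scatter). Among the measured compounds shown here, that step is small, but it is only a single step, and no compound carrying butyl has a measured number yet. The guide is therefore weak, and no shift beyond the scatter is expected in this assay.

The expected step is a 1.3-fold higher number from compound 1 to compound 3 (0.10 log units; within the scatter), so it should stay close to the numbers already seen. For compound 3 the estimated value is 1900000 nM, with an expected range from 800000 nM to 4500000 nM.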

Compound 3, half-maximal inhibitory concentration: 2000000 nM
Compound 3: the middle estimate sits 1.1-fold (0.02 log units) below what was measured, within the range that was stated.
By their numbers in this assay, from the lowest: compounds 1, 3 and 2 (each within the scatter of the next).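

In this assay, butyl in place of tert-butyl on a carbonyl carbon gives a 1.3-fold higher number from compound 1 to compound 3 (0.12 log units; within the scatter), and butyl in place of isopropyl on that same carbon gives a 1.3-fold lower number from compound 2 to compound 3 (0.10 log units; within the scatter). Before this result, the only step at this position removed one methyl from the tert-butyl group; this one keeps the same four carbon atoms and only joins them differently, and that rearrangement also stays within the scatter. The three groups tert-butyl, isopropyl and butyl therefore cannot be told apart on this read-out, so the shape of the carbon group on this carbonyl carbon shows no measurable influence among these three compounds, and nothing shown here offers an explanation for that.

On these data alone, all three groups are small saturated carbon groups, so it remains open whether a longer chain, a phenyl ring or a chain ending in an amine on this carbonyl carbon would move the number beyond the scatter. Also open, as far as these compounds go, is how a plain hydroxyl group, in place of the whole (butylcarbonyl)oxy unit on the shared core, would read in this assay.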